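Cyano for trifluoromethyl in an antiproliferative series

The source may report more compounds than this note shows. Statements on the series, on what has been measured and on what is new or still open speak of the compounds shown alone.

Measured in a functional assay on MCF7 cells (Homo sapiens) for antiproliferative activity, read by MTT assay, with a stated time of 72 h; on this read-out lower numbers stand for stronger inhibition and higher numbers for weaker inhibition:
- compound 1 `O=S1(=O)C=Cc2ccc(Nc3cccc(C(F)(F)F)c3)cc21`: 2500 nM
- compound 2 `O=S1(=O)C=Cc2ccc(Nc3ccc(C(F)(F)F)cc3)cc21`: 1270 nM

Compound 1 stands within the scatter of compound 2, so these two values give no order. Compound 3 `N#Cc1cccc(Nc2ccc3c(c2)S(=O)(=O)C=C3)c1`, not yet measured, has cyano in place of trifluoromethyl on an aromatic carbon, meta to a large group (cyano in place of trifluoromethyl on an aromatic carbon). Going by the values given here, no measured step covers this change, so the expectation in this assay is loose: the estimated 1.2-fold higher number from compound 1 to compound 3 (0.08 log units; within the scatter) is none beyond the scatter. For compound 3 the estimated value is 3000 nM, with an expected range of 1000 nM to 9000 nM.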

Compound 3, half-maximal inhibitory concentration: > 10000 nM
Compound 3: no number, only a limit (the forecaster's own chance of this, stated with the estimate: 10%); at least 3.3-fold (0.52 log units) between middle value and limit.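

In this assay, cyano in place of trifluoromethyl on this aromatic carbon, meta to a large group, is not a neutral exchange: it gives an at least 4.0-fold higher number from compound 1 to compound 3 (0.60 log units; beyond the scatter). Compound 3 gives > 10000 nM, which is a limit of the assay and not a number. The true size of the step therefore remains unknown, and only its lower bound can be read: the limit of > 10000 nM in this assay, at which 1 of the 3 values shown sits.

From the compounds shown here alone, whether other groups at this position, such as an amine or a carboxylic acid, keep the value of compound 1 stays open. Also open, going by these compounds, is whether cyano gives a similar step at the position that carries trifluoromethyl in compound 2.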